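Predicting a Side-Chain Carbamoyl Addition to Compound 1

The source may report more compounds than this note shows. Statements on the series, on what has been measured and on what is new or still open speak of the compounds shown alone.

Compound 1 `C[C@H](NC(=O)CN(c1nc(Cl)nc2[nH]cnc12)C1CC1)C(=O)OCc1ccccc1` is the strongest of the three measured compounds in a functional assay on the whole organism (Tail, strain ICR) with Mus musculus as the target, in the tail flick test, with a stated time of 60 min, at a dose of 25 umol/kg by the oral route (on this read-out lower numbers stand for a weaker effect and higher numbers for a stronger effect at the one dose given), giving 64.3%. Its nearest neighbour, compound 3 `C[C@H](NC(=O)CN(c1nc(Cl)nc2[nH]cnc12)C1CC1)C(=O)O`, gives 44.6%, and the furthest, compound 2 `CSCC[C@H](NC(=O)CN(c1nc(Cl)nc2[nH]cnc12)C1CC1)C(=O)O`, gives 22.8%.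

The unmeasured compound 4 `NC(=O)C[C@H](NC(=O)CN(c1nc(Cl)nc2[nH]cnc12)C1CC1)C(=O)OCc1ccccc1` differs from compound 1 in one place: carbamoyl in place of hydrogen on a saturated chain carbon, two bonds along the chain from an amide-type nitrogen and a carbonyl carbon.

Two measured steps help to judge this change. The step of a number 19.7 percentage points lower from compound 1 to compound 3 (beyond the scatter) shows that the benzyl ester matters, but that part is kept in compound 4. More directly relevant is the step of a number 21.8 percentage points higher from compound 2 to compound 3 (beyond the scatter), which shows that removing a side chain from the same saturated chain carbon raised the effect, so adding a side chain there went the other way. Carbamoyl is a different group from (methylsulfanyl)methyl, so the direction is expected to carry over only loosely, and the size is uncertain.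

On that basis, compound 4 is expected to show a modest drop in this assay relative to compound 1, a step of about a number 19.3 percentage points lower from compound 1 to compound 4 (beyond the scatter). The estimated value for compound 4 is 45%, with a range from 25% to 65%.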

Compound 4, a percentage reported as activity, at one dose (the size of the read-out at that dose, not a potency): 36.4%
Beside the measured number, compound 4's estimate is 8.6 percentage points above it; low and high end bracket the measured number.
By their numbers in this assay, from the lowest: compound 2; then compounds 4 and 3 (each within the scatter of the next); then compound 1.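

In this assay putting carbamoyl in place of hydrogen on this saturated chain carbon gives a number 27.9 percentage points lower from compound 1 to compound 4 (beyond the scatter) and so links a side chain at this place to a lower number in a compound that keeps the benzyl group. Until now that link rested on one pair with a different side chain and with hydrogen in place of benzyl, read as a number 21.8 percentage points higher from compound 2 to compound 3 (beyond the scatter) with hydrogen replacing (methylsulfanyl)methyl. The two pairs now point the same way for two different side chains, with no pair shown going against them, although nothing available explains why the number falls in either pair.

The compounds shown leave open whether other groups at this same place, such as an amine, a hydroxyl group or a plain ethyl chain, would also go with a lower number, or whether some side chain here could match or pass compound 1. They also leave open what carbamoyl at this place does in a compound with hydrogen in place of benzyl, where the carboxylic acid is kept.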